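The compounds below may be only part of what the source reports. "The series", "measured", "known", "first", "only" and "open" are said of these compounds alone.

In an ADME assay on NIH3T3 cells (Mus musculus) for inhibition, read by MTT assay, with a stated time of 48 h (a lower number here means a stronger inhibitor, a higher number a weaker inhibitor), compound 1 `Cc1ccc(-c2nc3ccccn3c2Sc2ccccc2)cc1` gives > 100000 nM, which is a limit of the assay and not a number. Compound 2 `c1ccc(Sc2c(-c3cccs3)nc3ccccn23)cc1` gives > 100000 nM, which is also a limit. Compound 2 therefore has no exact value and sits at the limit of > 100000 nM in this assay, at which 2 of the 2 values shown sit.

Compound 3 `c1ccc(Sc2c(-c3ccsc3)nc3ccccn23)cc1` keeps the same atoms but joins them differently, with thiophen-3-yl in place of thiophen-2-yl on an aromatic carbon. The ring stays the same and only its point of attachment moves.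

For the measured compounds named here, the one measured step that bears on this change is a step that the two limits leave unreadable from compound 1 to compound 2. It replaced 4-methylphenyl with thiophen-2-yl, and it offers no size to carry forward. Neither compound gave a number, so the data provide no sign of a change in either direction.

The expected change in this assay is therefore none beyond the usual scatter, and a number no higher from compound 2 to compound 3 (the limit leaves the size open) is the step estimated here. A further limit is the most likely report. For compound 3 the estimated value is 100000 nM, with an expected range from 50000 nM to 200000 nM.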

Compound 3, half-maximal inhibitory concentration: 94100 nM
Compound 3: middle estimate off by 1.1-fold (0.03 log units), on the high side; low and high end bracket the measured number.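

For the compounds shown here, compound 3 is the first compound here to give an exact number rather than a limit, so moving the attachment point of the thiophene ring is enough to bring a reading into the range that can be reported. In this assay, the isomer swap gives an at least 1.0-fold lower number from compound 2 to compound 3 (0.02 log units; that floor lies within the scatter), and replacing the original aryl group gives an at least 1.0-fold lower number from compound 1 to compound 3 (0.02 log units; that floor lies within the scatter). Compound 2 remains a limit and not a number, so each of these steps is only a floor, neither shows a change beyond the scatter, and the series stays at the edge of what can be read: the limit of > 100000 nM in this assay, at which 2 of the 3 values shown sit.

Going by these compounds, the true size of the difference between thiophen-2-yl and thiophen-3-yl therefore remains open, and so does whether the point of attachment matters at all on this aromatic carbon. Also open, on these data alone, is whether a different group at this place, such as a pyridine ring, an amine or a carboxylic acid, would give a number clearly lower than that of compound 3 94100 nM.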